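The compounds below may be only part of what the source reports. "The series", "measured", "known", "first", "only" and "open" are said of these compounds alone.

Measured so far in a functional assay on MIA PaCa-2 cells (Homo sapiens) for inhibition, read by MTT assay, with a stated time of 3 days; on this read-out lower numbers stand for stronger inhibition and higher numbers for weaker inhibition:
compound 1 `CCN(CC)S(=O)(=O)c1ccc(S(=O)(=O)N2CCC[C@@H](C(=O)N3CCC(OC)CC3)C2)cc1` gives > 10000 nM, a limit.
compound 2 `CC(C)S(=O)(=O)c1ccc(S(=O)(=O)N2CCC[C@@H](C(=O)N3CCC(F)(F)CC3)C2)cc1` gives > 3000 nM, a limit.
compound 3 `CCN(CC)S(=O)(=O)c1ccc(S(=O)(=O)N2CCC[C@@H](C(=O)N[C@H]3CCOC3)C2)cc1` gives > 10000 nM, a limit.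

Compound 1 thus stands only at a limit in this assay, and the other two values shown are limits as well (the limit of > 10000 nM in this assay, at which 2 of the 3 values shown sit, (the limit of > 3000 nM in this assay, at which 1 of the 3 values shown sits)). Compound 4 `CCN(CC)S(=O)(=O)c1ccc(S(=O)(=O)N2CCC[C@@H](C(=O)N3CC[C@@H](OC)C3)C2)cc1` is not yet measured; it differs from compound 1 by 3-methoxypyrrolidin-1-yl in place of 4-methoxypiperidin-1-yl on a carbonyl carbon. For the measured compounds named here, the one comparable step, a step that the two limits leave unreadable from compound 1 to compound 3, also changes the group on the same carbonyl carbon, and its size cannot be read from two limits. No readable step is available, so no shift beyond the scatter is expected in either direction in this assay. The step is expected to be a step that the limit leaves unreadable from compound 1 to compound 4. Compound 4 is estimated at 20000 nM, within 5000 nM to 80000 nM, most likely reported again only as a limit.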

Compound 4, half-maximal inhibitory concentration: > 10000 nM
Compound 4 gave a limit, no number; the forecaster's own chance of this, stated with the estimate: 85%; the middle value does not contradict the limit.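

In this assay compound 4 gives > 10000 nM, a limit. Compound 1 and compound 3 also stand only at limits, so neither step to compound 4 can be read. The compounds shown leave open whether any group on this carbonyl carbon gives a number rather than a limit.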